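Replacing the ethyl group on the ester of compound 3

The source may hold more compounds than are shown below. What is called first, only, known or untested is meant among the compounds shown, and "the series" means these compounds.

Measured values in a functional assay on SK-BR-3 cells (Homo sapiens) for cytotoxicity, read by MTT assay, with a stated time of 72 h (a lower number here means that less compound is needed, a higher number that more compound is needed for the effect), are as follows
- compound 1 `CCc1cccc2c(O)c(-c3occ(C)c3C(=O)O)ccc12` gives 1 ug/mL
- compound 2 `CCOc1c(-c2occ(C)c2C(=O)O)ccc2c(CC)cccc12` gives > 10 ug/mL as a limit
- compound 3 `CCOC(=O)c1c(C)coc1-c1ccc2c(CC)cccc2c1OC` gives 2.5 ug/mL

Of the two numbers in this assay compound 3 stands higher. Compound 3 gives 2.5 ug/mL and compound 1 gives 1 ug/mL with the gap beyond the scatter.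

Compound 4 `CCc1cccc2c(OC)c(-c3occ(C)c3C(=O)On3nnc4ccccc43)ccc12` differs from compound 3 in one place (a group of 9 heavy atoms (6 carbon, 3 nitrogen; one five-membered aromatic ring with 3 hetero atoms, one six-membered aromatic ring of carbon only) in place of a group of 2 heavy atoms (2 carbon; no ring), on an oxygen next to a carbonyl group). On an oxygen next to a carbonyl group, ethyl leaves and a group with one five-membered aromatic ring with 3 hetero atoms and one six-membered aromatic ring of carbon only enters.

For the measured compounds named here, the one measured step of an at least 10-fold higher number from compound 1 to compound 2 (1.00 log units; beyond the scatter) bears only loosely on this. It puts ethyl in place of hydrogen on an oxygen on an aromatic ring, a different place, and the limit of > 10 ug/mL in this assay, at which 1 of the 3 values shown sits, makes its size a bound only. Going by the values given here, no measured step covers the oxygen that changes here, so no step beyond the scatter is expected in this assay for this change. The expected step of a 1.2-fold higher number from compound 3 to compound 4 (0.08 log units; within the scatter) is therefore small, with wide uncertainty. In this assay the estimated value of compound 4 is 3 ug/mL with 0.8 ug/mL to 10 ug/mL as the expected range.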

Compound 4, concentration for half-maximal effect: > 10 ug/mL
Compound 4 ended at the assay's limit (the forecaster's own chance of this, stated with the estimate: 15%); at least 3.3-fold (0.52 log units) between middle value and limit.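

In this assay, placing the group with one five-membered aromatic ring with 3 hetero atoms and one six-membered aromatic ring of carbon only on the oxygen next to a carbonyl group, where ethyl stood, gives an at least 4.0-fold higher number from compound 3 to compound 4 (0.60 log units; beyond the scatter). This oxygen is therefore a place where a change moves the read-out beyond the scatter, which the earlier step, on an oxygen on an aromatic ring, could not show. Compound 4 gives > 10 ug/mL, which is a limit, so the step is a bound only: the limit of > 10 ug/mL in this assay, at which 2 of the 4 values shown sit.

As far as these compounds go, how far the number rises with this change stays open, as does which part of the entering group matters. A propyl chain or a benzyl group on this oxygen would show whether the ethyl of compound 3 can be replaced at all without a step beyond the scatter.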